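The compounds below may be only part of what the source reports. "The series", "measured", "known", "first", "only" and "open" are said of these compounds alone.

In a functional assay on the whole organism for inhibition, with Mus musculus as the target (a higher number here means that more compound is needed for the effect, a lower number that less compound is needed), compound 1 `CN1Cc2c(N)cccc2C(c2ccc(Cl)cc2)C1` gives 1.6 mg/kg, and compound 2 `CN1Cc2c(N)cccc2C(c2ccc(F)cc2)C1` gives about 3.6 mg/kg. Swapping chloro for fluoro on an aromatic carbon accounts for a 2.3-fold higher number from compound 1 to compound 2 (0.35 log units; beyond the scatter), a modest change.

Compound 3 `CCCNC(=O)Nc1cccc2c1CN(C)CC2c1ccccc1` has no number in this assay, only a limit of > 80 mg/kg. That value is the limit of > 80 mg/kg in this assay, at which 1 of the 3 values shown sits.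

Compound 4 `CCCCNCC(=O)Nc1cccc2c1CN(C)CC2c1ccccc1` keeps the shared core of compound 3 and changes one group: (butylamino)methyl stands in place of propylamino on a carbonyl carbon, ((butylamino)methyl in place of propylamino on a carbonyl carbon).

Among the measured compounds shown here, no measured step covers this change. For the measured compounds named here, the single step between compound 1 and compound 2 lies elsewhere on the molecule, so it offers only a sense of scale and no direct guide. The low value of compound 1, 1.6 mg/kg, shows that a close relative of this core can work at small doses, which leans the expectation towards a lower number. Even so, a second result that is only a limit would not be surprising.

In this assay, the expected change is an at least 3.2-fold lower number from compound 3 to compound 4 (0.50 log units; beyond the scatter), and it is a rough figure since it starts from a limit. For compound 4 the estimated value is 25 mg/kg, with an expected range from 4 mg/kg to 120 mg/kg.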

Compound 4, dose for half-maximal effect: 32 mg/kg
For compound 4 the middle estimate is 1.3-fold (0.11 log units) below the measured one; measured number inside the range.
By their numbers in this assay, from the lowest: compound 1; then compound 2; then compound 4. At a limit, above all of these: compound 3.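

Until now this position had offered only a limit, so nothing showed that a compound with a group on this carbonyl carbon could reach a measurable dose in this assay. Putting (butylamino)methyl in place of propylamino gives an at least 2.5-fold lower number from compound 3 to compound 4 (0.39 log units; beyond the scatter), which shows that the number responds to the group placed here, even though the core stays the same. Compound 3 holds only a limit and not a number, so this step gives a minimum and its true size stays unknown: the limit of > 80 mg/kg in this assay, at which 1 of the 4 values shown sits.

The step also changes several things at once, as the group grows from 4 to 6 heavy atoms and gains a hydrogen-bond acceptor, and the compounds shown cannot separate these changes from one another. Going by these compounds, it remains open how (propylamino)methyl, with a shorter chain on the same nitrogen, or aminomethyl, a free amine, would behave on this carbonyl carbon, and whether either would bring the number lower than compound 4 gives.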